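The source may hold more compounds than are shown below. What is called first, only, known or untested is meant among the compounds shown, and "the series" means these compounds.

Measured in a functional assay on MCF7 cells (Homo sapiens) for antiproliferative activity, read by CellTiter-Glo, with a stated time of 5 days; a lower number here means a stronger inhibitor, a higher number a weaker inhibitor:
- Compound 1 `CC/C(=C(/c1ccc(/C=C/C(=O)O)cc1)c1ccc2[nH]ncc2c1)c1ccccc1`: 7.2 nM
- Compound 2 `CC/C(=C(/c1ccc(/C=C/C(=O)O)cc1)c1ccc2c(cnn2C)c1)c1ccccc1`: 300 nM
- Compound 3 `CC/C(=C(/c1ccc(/C=C/C(=O)O)cc1)c1ccn2ccnc2c1)c1ccccc1`: > 500 nM, a limit

Compound 3 has no number, only a limit: the limit of > 500 nM in this assay, at which 1 of the 3 values shown sits. Compound 4 `CC/C(=C(/c1ccc(/C=C/C(=O)O)cc1)c1ccc2nncn2c1)c1ccccc1` differs from it as follows: a group of 9 heavy atoms (6 carbon, 3 nitrogen; one five-membered aromatic ring with 3 hetero atoms, one six-membered aromatic ring with 1 hetero atom) in place of a group of 9 heavy atoms (7 carbon, 2 nitrogen; one five-membered aromatic ring with 2 hetero atoms, one six-membered aromatic ring with 1 hetero atom), on a double-bonded chain carbon bound to an aromatic carbon and a double-bonded chain carbon. Two measured changes at this place bear on that swap. One is large, an at least 69-fold higher number from compound 1 to compound 3 (1.84 log units; beyond the scatter). The other is an at least 1.6-fold higher number from compound 2 to compound 3 (0.22 log units; that floor lies within the scatter). The large 42-fold higher number from compound 1 to compound 2 (1.62 log units; beyond the scatter) concerns a methyl in place of hydrogen on an aromatic nitrogen. In this assay, no step beyond the scatter is expected, with any shift tending towards a higher number. The expected change is a step that the limit leaves unreadable from compound 3 to compound 4. Compound 4 is estimated at 800 nM, with an expected range of 250 nM to 2500 nM.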

Compound 4, half-maximal inhibitory concentration: > 500 nM
Compound 4: only a limit was reported (the forecaster's own chance of this, stated with the estimate: 65%); the middle value lies beyond the limit too.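

In this assay, a second group with a six-membered aromatic ring with 1 hetero atom, this one with a five-membered aromatic ring with 3 hetero atoms, also ends in a limit, so compound 3 is not alone at this place: the limit of > 500 nM in this assay, at which 2 of the 4 values shown sit. The change gives an at least 69-fold higher number from compound 1 to compound 4 (1.84 log units; beyond the scatter) and, with a floor inside the scatter, an at least 1.6-fold higher number from compound 2 to compound 4 (0.22 log units; that floor lies within the scatter). The step from compound 3 to compound 4 cannot be read, as both are limits.

On these data alone, how far compound 3 and compound 4 lie past their limits stays open. So does whether a group carrying an amine at this place would move back towards compound 1.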